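Phenyl to 1H-imidazol-1-yl: working notes on compound 4

This account rests on a few compounds, and the source may have more. Where it says the series, first, only, none or still open, it means among the compounds named here.

Compound 1 (`CCN(c1cccc(-c2ccccc2)c1)c1ccc(C#N)c(Cl)c1`) has no single number in a functional assay on PC-3 cells (Homo sapiens) for antiproliferative activity, read by CCK-8 assay, with a stated time of 6 days (on this read-out higher numbers stand for weaker inhibition and lower numbers for stronger inhibition), and stands as "not determined" (no result reported) there. Compound 3 (`CCN(c1ccc(C#N)c(Cl)c1)c1cc(-c2ccccc2)ccc1C`) likewise stands as "not determined" (no result reported) in this series. Compound 2 (`CCN(c1ccc(C#N)c(Cl)c1)c1cc(-n2cnc3ccccc32)ccc1C`) alone carries a number, with 8160 nM as its reading in this assay here. Still unmeasured is compound 4 (`CCN(c1cccc(-n2ccnc2)c1)c1ccc(C#N)c(Cl)c1`). The change 1H-imidazol-1-yl in place of phenyl on an aromatic carbon puts 1H-imidazol-1-yl in place of phenyl on an aromatic carbon. Within the data shown here, the series offers no measured step and compound 1 offers no starting number, so the step expected in this assay is none beyond the scatter around the sole reading of compound 2. Compound 4 is estimated at 8000 nM with an expected range from 2500 nM to 25000 nM in this read-out.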

Compound 4, half-maximal inhibitory concentration: > 30000 nM
Compound 4: only a limit was reported; the forecaster's own chance of this, stated with the estimate: 20%; middle value at least 3.7-fold (0.57 log units) from the limit.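

In this assay, among these compounds, compound 4 gives > 30000 nM as a limit and not a number, and compound 1 has no single number, so no step between them can be read. Left open is how in this assay phenyl and 1H-imidazol-1-yl compare on the shared core.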